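Amide side chain change from compound 2 to compound 3

A few compounds are considered here, and "the series" means these few. Any claim that something is new, unique, unknown or untested is made for them only; others in the source may bear on it.

Values in an ADME assay on MT4 cells (Homo sapiens) for cytotoxicity, read by MTT assay (a lower number here means that less compound is tolerated, a higher number that more compound is tolerated), so far
- compound 1 (`Cc1cc(C)cc(S(=O)(=O)c2c(C(=O)Nc3ccccc3O)[nH]c3ccc(Cl)cc23)c1`) gives 19700 nM in this series
- compound 2 (`Cc1cc(C)cc(S(=O)(=O)c2c(C(=O)NCc3cccc(O)c3)[nH]c3ccc(Cl)cc23)c1`) gives 27000 nM in this series

Going by the values given here, compound 2 stands within the scatter of compound 1, the only other measured compound. Compound 3 (`Cc1cc(C)cc(S(=O)(=O)c2c(C(=O)NCC(=O)NCc3ccccc3O)[nH]c3ccc(Cl)cc23)c1`) carries (2-hydroxybenzyl)carbamoyl in place of 3-hydroxyphenyl on a saturated chain carbon bound to an amide-type nitrogen. Among the compounds with values here, the one measured step bearing on this is a 1.4-fold higher number from compound 1 to compound 2 (0.14 log units; within the scatter), with 3-hydroxybenzyl in place of 2-hydroxyphenyl on an amide-type nitrogen. On that basis, no step beyond the scatter is expected in this assay. The expected step is a 1.1-fold lower number from compound 2 to compound 3 (0.05 log units; within the scatter), in estimate only. Compound 3 is estimated at 24000 nM, with an expected range of 11000 nM to 50000 nM.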

Compound 3, half-maximal cytotoxic concentration: > 47300 nM
Compound 3 gave a limit, no number; the forecaster's own chance of this, stated with the estimate: 15%; middle value at least 1.9-fold (0.29 log units) from the limit.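

In this assay, (2-hydroxybenzyl)carbamoyl in place of 3-hydroxyphenyl on a saturated chain carbon bound to an amide-type nitrogen gives an at least 1.7-fold higher number from compound 2 to compound 3 (0.24 log units; that floor lies within the scatter). Going by these compounds alone, on the amide-type nitrogen, the larger group gives an at least 2.4-fold higher number from compound 1 to compound 3 (0.38 log units; beyond the scatter), the first step beyond the scatter. The result for compound 3 is a limit of the assay and not a number: the limit of > 47300 nM in this assay, at which 1 of the 3 values shown sits.

As far as these compounds go, the true size of both steps remains open. From the compounds shown here alone, it is also open whether the carbamoyl unit or the 2-hydroxybenzyl group accounts for the step, and how an amine or a carboxylic acid in that place would read.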